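The compounds below may be only part of what the source reports. "The series", "measured", "known", "first", "only" and "open" are said of these compounds alone.

Measured so far:
compound 1, `Cc1ccc(NC(=O)C(C)NS(=O)(=O)c2cccc3cccnc23)c(C)c1`: > 50000 nM
compound 2, `CCc1ccccc1NC(=O)[C@@H]1CCCN1S(=O)(=O)c1cccc2cccnc12`: > 50000 nM
compound 3, `Cc1ccc(C(C)(C)C)cc1NC(=O)[C@@H]1CCCN1S(=O)(=O)c1cccc2cccnc12`: 6500 nM

In an ADME assay on HEp-2 cells (Homo sapiens) for cytotoxicity (a higher number here means that more compound is tolerated, a lower number that less compound is tolerated), compound 2 gives only a limit, > 50000 nM, and not a number. Compound 1 sits at the same limit, so two of the three values shown are limits, as the limit of > 50000 nM in this assay, at which 2 of the 3 values shown sit, records. Among the measured compounds shown here, compound 3 is the one compound with a measured number, 6500 nM, so it is the only point that shows how far tolerance can fall within this set. Compound 4, `Cc1ccc(Cl)c(NC(=O)[C@@H]2CCCN2S(=O)(=O)c2cccc3cccnc23)c1`, has not been measured in this assay. It differs from compound 2 in one place: 2-chloro-5-methylphenyl in place of 2-ethylphenyl on an amide-type nitrogen. The change sits on the amide-type nitrogen whose other neighbour is the carbonyl carbon. For the measured compounds named here, with no measured step between any two of the three compounds, the account can offer no measured size for such a change. Compound 4 is expected to stay near the limit, with at most a modest step of an at least 1.4-fold lower number from compound 2 to compound 4 (0.15 log units; that floor lies within the scatter) toward the number of compound 3. For compound 4 the estimate is 35000 nM, within 12000 nM to 50000 nM.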

Compound 4, half-maximal cytotoxic concentration: > 50000 nM
Compound 4 was reported as a limit; the forecaster's own chance of this, stated with the estimate: 55%; at least 1.4-fold (0.15 log units) between middle value and limit.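

In this assay compound 4 gives > 50000 nM, which is a limit and not a number. Compound 2 also gives only a limit, so no step can be read between compound 2 and compound 4: the limit of > 50000 nM in this assay, at which 3 of the 4 values shown sit. The compounds shown leave open whether 2-chloro-5-methylphenyl and 2-ethylphenyl differ at all in this assay.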